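This account rests on a few compounds, and the source may have more. Where it says the series, first, only, none or still open, it means among the compounds named here.

Within the data shown here, compound 2 `O=C(CSc1nc2ccc(NC(=O)c3ccccc3)cc2s1)NCc1ccccc1` is one of two compounds measured in a functional assay on HepG2 cells (Homo sapiens) for cytotoxicity, read by MTT assay, with a stated time of 48 h (a lower number here means a stronger inhibitor, a higher number a weaker inhibitor), where compound 2 gives 34200 nM. The other, compound 1 `CNC(=O)CSc1nc2ccc(NC(=O)c3ccccc3OC)cc2s1`, carries a methoxy group and a different amide end; in this assay compound 1 gives 18500 nM, and the two numbers lie within the usual scatter of each other. Compound 3 `COc1ccccc1C(=O)Nc1ccc2nc(SCC(=O)NCc3ccccc3)sc2c1` differs from compound 2 by methoxy in place of hydrogen on an aromatic carbon. With only these two numbers as a guide, no step beyond the scatter is expected from compound 2 to compound 3 a 1.4-fold lower number from compound 2 to compound 3 (0.14 log units; within the scatter). Compound 3 is therefore estimated at 25000 nM, with a range from 10000 nM to 60000 nM.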

Compound 3, half-maximal inhibitory concentration: 8000 nM
Estimate against measurement, compound 3: 3.1-fold (0.49 log units) above; measured number outside the range, below it.
By their numbers in this assay, from the lowest: compound 3; then compounds 1 and 2 (each within the scatter of the next).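

Going from phenyl to 2-methoxyphenyl gives the first step in this assay that clearly exceeds the scatter, a 4.3-fold lower number from compound 2 to compound 3 (0.63 log units; beyond the scatter), so this ring position can affect the reading. With the methoxy present, the amide end also counts: a 2.3-fold lower number from compound 1 to compound 3 (0.36 log units; beyond the scatter) comes with phenyl in place of hydrogen on the saturated chain carbon. Nothing here bears on the reason for either step. Still open, going by these compounds, is whether ethoxy or a hydroxyl group at the same ring carbon would give a similar number, and whether the methoxy step would recur with an amide end carrying an amine.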